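Compound 3 to compound 4: shifting the bromine

The compounds below may be only part of what the source reports. "The series", "measured", "known", "first", "only" and "open" are said of these compounds alone.

In a functional assay on MCF7 cells (Homo sapiens) for inhibition, read by MTT assay, with a stated time of 72 h (a lower number here means a stronger inhibitor, a higher number a weaker inhibitor), compound 1 `Cc1cc(Nc2cc(-c3ccccc3)[nH]n2)n2nc(SCc3ccc([N+](=O)[O-])cc3)nc2n1` gives 5060 nM, and compound 3 `Cc1cc(Nc2cc(-c3ccccc3)[nH]n2)n2nc(SCc3cccc(Br)c3)nc2n1` gives 5140 nM. The two stand level, with a 1.0-fold higher number from compound 1 to compound 3 (0.01 log units; within the scatter). Compound 2 `Cc1cc(Nc2cc(-c3ccccc3)[nH]n2)n2nc(SCC3CCCCC3)nc2n1`, with cyclohexyl on the same chain carbon, gives > 50000 nM, which is a limit of the assay. Its steps to the two aromatic compounds are an at least 9.8-fold higher number from compound 1 to compound 2 (0.99 log units; beyond the scatter) and an at least 9.7-fold lower number from compound 2 to compound 3 (0.98 log units; beyond the scatter), the only changes among these three compounds that go beyond the scatter.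

Compound 4 `Cc1cc(Nc2cc(-c3ccccc3)[nH]n2)n2nc(SCc3ccccc3Br)nc2n1` carries 2-bromophenyl in place of 3-bromophenyl on a saturated chain carbon bound to a sulfur. The aromatic ring stays, so the large cyclohexyl steps offer little guidance. For the measured compounds named here, no measured compound carries 2-bromophenyl. The nearest guide is the exchange of 4-nitrophenyl for 3-bromophenyl, a 1.0-fold higher number from compound 1 to compound 3 (0.01 log units; within the scatter), so no change beyond the scatter is expected in this assay, and no direction is favoured. The estimated step is a 1.1-fold higher number from compound 3 to compound 4 (0.03 log units; within the scatter). For compound 4 the estimated value is 5500 nM, with an expected range of 2200 nM to 14000 nM.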

Compound 4, half-maximal inhibitory concentration: 3020 nM
The estimate for compound 4 lay 1.8-fold (0.26 log units) above the measured number, and the stated range covers the measured number.
By their numbers in this assay, from the lowest: compounds 4, 1 and 3 (each within the scatter of the next). At a limit, above all of these: compound 2.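

In this assay, moving the bromine to give 2-bromophenyl on a saturated chain carbon bound to a sulfur opens no gap beyond the scatter, either against 3-bromophenyl (a 1.7-fold lower number from compound 3 to compound 4 (0.23 log units; within the scatter)) or against 4-nitrophenyl (a 1.7-fold lower number from compound 1 to compound 4 (0.22 log units; within the scatter)), so compounds 1, 3 and 4 stand level. The aromatic group of compound 4 also stands well apart from cyclohexyl (an at least 16-fold lower number from compound 2 to compound 4 (1.21 log units; beyond the scatter)), a third aromatic compound separated from compound 2. The value of compound 2 is a limit: the limit of > 50000 nM in this assay, at which 1 of the 4 values shown sits.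

Open, as far as these compounds go, is whether 4-bromophenyl or unsubstituted phenyl would stay level with these three compounds. Also open, from the compounds shown here alone, is whether an amine, a carboxylic acid or a longer chain at this place would move the number beyond the scatter.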